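The source may hold more compounds than are shown below. What is called first, only, known or untested is meant among the compounds shown, and "the series" means these compounds.

Compound 1, with the structure `CC(=O)Nc1ccc(CN2CCC=C(CCC(=O)NO)C2=O)cc1`, has no result in a functional assay on NUGC-3 cells (Homo sapiens) for inhibition, read by sulforhodamine B assay; on this read-out higher numbers stand for weaker inhibition of growth and lower numbers for stronger inhibition of growth: in that assay compound 1 is recorded as "not determined" (no result reported), so compound 1 stands on no number at all. Among the measured compounds shown here, the one measured compound is compound 2, with the structure `O=C(CCC1=CCCN(CCCc2ccc3ccccc3c2)C1=O)NO`. In this assay compound 2 gives 790 nM, which gives a sense of the range in which this hydroxamic acid series acts on the growth of these cells.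

Compound 3, with the structure `O=C(CCC1=CCCN(Cc2ccc([N+](=O)[O-])cc2)C1=O)NO`, has not yet been measured. It differs from compound 1 in one place: nitro in place of acetamido on an aromatic carbon. The change sits on an aromatic carbon of a six-membered aromatic ring of carbon only, while the rest of the molecule, including the hydroxamic acid chain and the shared core, is unchanged.

For the measured compounds named here, no measured pair in this set shows what such a swap does, and compound 1 itself gives no anchor, so the direction of the step in this assay cannot be read from the data. I expect compound 3 to land near compound 2, at about 1500 nM, within a range of 400 nM to 6000 nM.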

Compound 3, concentration for 50% growth inhibition: 1110 nM
Estimate against measurement, compound 3: 1.4-fold (0.13 log units) above; low and high end bracket the measured number.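

No step can be read from compound 1 to compound 3: in this assay compound 3 gives 1110 nM, while compound 1 offers no number to compare it with. What replacing acetamido with nitro does to growth inhibition stays open, and nothing shown here helps explain the value of compound 3.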